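The source may hold more compounds than are shown below. What is called first, only, known or untested is meant among the compounds shown, and "the series" means these compounds.

Compound 2 `O=C1CC2(CO1)CSC(=S)N2c1ccc(F)cc1` carries the shared core of compound 1 `O=C1CC2(CO1)CSC(=S)N2c1ccccc1` with a fluoro on the aromatic carbon. In a functional assay on PC-3 cells (Homo sapiens) for antiproliferative activity, read by MTT assay, with a stated time of 72 h (a higher number here means a weaker inhibitor, a lower number a stronger inhibitor), compound 1 gives only a limit, > 50 ug/mL. In this assay compound 2 likewise gives only a limit, > 50 ug/mL. The step that the two limits leave unreadable from compound 1 to compound 2 is therefore not readable; both values sit at the limit of > 50 ug/mL in this assay, at which 2 of the 2 values shown sit. Compound 3 `O=C1CC2(CO1)CSC(=S)N2c1ccc(Cl)cc1` differs from compound 2 by chloro in place of fluoro on an aromatic carbon. For the measured compounds named here, no measured step bears on this change, so no shift beyond the scatter is expected, and a step that the limit leaves unreadable from compound 2 to compound 3 is estimated as flat. Compound 3 is expected at 60 ug/mL, within 30 ug/mL to 150 ug/mL.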

Compound 3, half-maximal inhibitory concentration: > 50 ug/mL
Compound 3: only a limit was reported; the forecaster's own chance of this, stated with the estimate: 75%; the middle value is on the limit's open side.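

No step among compound 1, compound 2 and compound 3 can be read, as all three values are limits: the limit of > 50 ug/mL in this assay, at which 3 of the 3 values shown sit.

The compounds shown leave open how hydrogen, fluoro and chloro on the aromatic carbon rank in this assay.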